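This account rests on a few compounds, and the source may have more. Where it says the series, first, only, none or still open, it means among the compounds named here.

Compound 1 `CCCCCCCC/C=C\CCCCCCC(=O)c1nc2cnccc2o1` carries an α-keto heteroaryl group on a long unsaturated chain and in an assay on isolated protein for inhibition of Fatty-acid amide hydrolase 1 (Homo sapiens) (on this read-out higher numbers stand for weaker inhibition and lower numbers for stronger inhibition), compound 1 gives 7.2 nM. Compound 2 `CCCCCCCC/C=C\CCCCCCC(=O)c1ccccc1` replaces that group with a plain phenyl ring. In this assay compound 2 reaches only the limit of > 100000 nM, so it has no number of its own. The step of an at least 13000-fold higher number from compound 1 to compound 2 (4.14 log units; beyond the scatter) is therefore known only as a lower bound, since (the limit of > 100000 nM in this assay, at which 1 of the 2 values shown sits).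

Compound 3 `CCCCCCCC/C=C\CCCCCCC(=O)c1nccn1C` is the third member: 1-methyl-1H-imidazol-2-yl in place of phenyl on a carbonyl carbon. Within the data shown here, the only measured step that bears on it is the removal of the heteroaryl ketone from compound 1 to compound 2, which cut the inhibition by a very large margin. Compound 3 brings back a five-membered aromatic ring with two hetero atoms and two hydrogen-bond acceptors, which points the step back in the direction of stronger inhibition, though not necessarily to the level of compound 1. The estimate for compound 3 in this assay is 3000 nM, with a range from 300 nM to 30000 nM, corresponding to the expected step of an at least 33-fold lower number from compound 2 to compound 3 (1.52 log units; beyond the scatter).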

Compound 3, inhibition constant: > 100000 nM
Compound 3: only a limit was reported; the forecaster's own chance of this, stated with the estimate: 10%; middle value at least 33-fold (1.52 log units) from the limit.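

In this assay compound 3 also stops at a limit, > 100000 nM, and this is not a number of its own. The step of an at least 13000-fold higher number from compound 1 to compound 3 (4.14 log units; beyond the scatter) shows that, on this carbonyl carbon, a five-membered aromatic ring with 2 hetero atoms is not enough on its own to keep inhibition at the level of compound 1; the 1-methyl-1H-imidazol-2-yl group, with its 2 hydrogen-bond acceptors, does not restore a measurable value in this series. The step between the phenyl of compound 2 and the 1-methyl-1H-imidazol-2-yl of compound 3 cannot be read, so the two groups cannot be ranked, because both compounds sit at the same ceiling: the limit of > 100000 nM in this assay, at which 2 of the 3 values shown sit.

The compounds shown leave open which part of the group in compound 1 accounts for the difference, since compound 3 differs from it in more than one feature of that group, including the ring oxygen and the six-membered aromatic ring with 1 hetero atom. From the compounds shown here alone, it also remains open whether a pyridine ring or an unmethylated imidazol-2-yl ring on the carbonyl carbon would give a value inside the range of the assay.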